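A few compounds are considered here, and "the series" means these few. Any claim that something is new, unique, unknown or untested is made for them only; others in the source may bear on it.

Compound 1 `OC[C@H]1O[C@@H](n2cnc3c(NCc4ccccc4Cl)ncnc32)[C@H](O)[C@@H]1O` belongs to a small set of compounds in which a substituted benzyl group hangs from a nitrogen on the shared core, and the set was tested in a functional assay on G-361 cells (Homo sapiens) for antiproliferative activity, with a stated time of 72 h; on this read-out higher numbers stand for weaker inhibition and lower numbers for stronger inhibition. Compound 1 itself has no single number in this assay; its entry simply reads "not determined" (no result reported). Two relatives show where the set sits. Compound 2 `COc1ccccc1CNc1ncnc2c1ncn2[C@@H]1O[C@H](CO)[C@@H](O)[C@H]1O` reaches only a limit of this assay, recorded as > 166000 nM. Compound 3 `OC[C@H]1O[C@@H](n2cnc3c(NCc4ccc(Cl)cc4Cl)ncnc32)[C@H](O)[C@@H]1O` gives 128000 nM in this assay. The move from compound 2 to compound 3, with 2,4-dichlorophenyl in place of 2-methoxyphenyl on a saturated chain carbon bound to a nitrogen on an aromatic ring, yields an at least 1.2-fold lower number from compound 2 to compound 3 (0.11 log units; that floor lies within the scatter). One of the three values in the set sits at the limit of > 166000 nM in this assay, at which 1 of the 3 values shown sits.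

Compound 4 `Cc1cccc(CNc2ncnc3c2ncn3[C@@H]2O[C@H](CO)[C@@H](O)[C@H]2O)c1O` differs from compound 1 in the same region: 2-hydroxy-3-methylphenyl in place of 2-chlorophenyl on a saturated chain carbon bound to a nitrogen on an aromatic ring. Among the compounds with values here, no measured step in the set touches 2-hydroxy-3-methylphenyl or 2-chlorophenyl, so the only guide is the general level, and every read-out so far speaks for weak inhibition whatever group sits on that chain carbon. Compound 4 is therefore expected to land in the same weak region, at an estimated 150000 nM with a range from 50000 nM to 500000 nM, and with a real chance that this assay returns only a limit for it.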

Compound 4, half-maximal inhibitory concentration: > 166000 nM
Compound 4 gave a limit, no number; the forecaster's own chance of this, stated with the estimate: 50%; middle value at least 1.1-fold (0.04 log units) from the limit.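

In this assay compound 4 returns only a limit, > 166000 nM, and not a number. Putting 2-hydroxy-3-methylphenyl in place of 2,4-dichlorophenyl on the saturated chain carbon gives an at least 1.2-fold higher number from compound 3 to compound 4 (0.11 log units; that floor lies within the scatter), so this change cannot be told apart from no change, and the step between the two limits, from compound 2 to compound 4, cannot be read. The ring of compound 4 is the first benzyl ring here to carry a hydrogen-bond donor, yet compound 4 stays in the same weak region as the methoxy-bearing compound 2 and the dichloro-bearing compound 3, with the read-out again stopping at the assay's limit: the limit of > 166000 nM in this assay, at which 2 of the 4 values shown sit.

From the compounds shown here alone, how far compound 2 and compound 4 lie past that limit remains unknown, and with no result for compound 1, the change from 2-chlorobenzyl to 2-hydroxy-3-methylbenzyl has no size. Also open, going by these compounds, is whether an amine or a carboxylic acid on the benzyl ring, or a longer chain in place of the benzyl group, would give a clearly lower number in this assay.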